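A few compounds are considered here, and "the series" means these few. Any claim that something is new, unique, unknown or untested is made for them only; others in the source may bear on it.

Compound 1, `Cc1cc2c(-c3ccc(F)cc3)c(/C=C/[C@@H](O)C[C@@H](O)CC(=O)O)c(C(C)C)nc2s1`, gives -21.5% in an in vivo functional assay on the whole organism for inhibition of 3-hydroxy-3-methylglutaryl-coenzyme A reductase (Rattus norvegicus), at a dose of 0.2 mg/kg by the oral route; on this read-out lower numbers stand for a weaker effect and higher numbers for a stronger effect at the one dose given.
Compound 2, `CC(C)c1cc2c(-c3ccc(F)cc3)c(/C=C/[C@@H](O)C[C@@H](O)CC(=O)O)c(C(C)C)nc2s1`, gives -71.5% in this assay.
Compound 3, `CC(C)c1cc2nc(C3CC3)c(/C=C/[C@@H](O)C[C@@H](O)CC(=O)O)c(-c3ccc(F)cc3)n2n1`, gives 21.8% in this assay.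

Compound 1 and compound 2 share one core; compound 3 has another, and the difference between the two cores is not broken down here. Within the first core the change is methyl in place of isopropyl on an aromatic carbon, and it produced a number 50 percentage points higher from compound 2 to compound 1 (beyond the scatter). Compound 3 stands highest of the three, beyond the scatter against both others. Compound 4, `Cc1cc2nc(C3CC3)c(/C=C/[C@@H](O)C[C@@H](O)CC(=O)O)c(-c3ccc(F)cc3)n2n1`, differs from compound 3 by methyl in place of isopropyl on an aromatic carbon. This is the same kind of change, not the same: here the group sits on a five-membered aromatic ring with 2 nitrogen, next to the ring nitrogen, whereas in compound 1 it sits on a five-membered aromatic ring with 1 sulfur, next to the ring sulfur. Resting on the single earlier step of a number 50 percentage points higher from compound 2 to compound 1 (beyond the scatter), a step of a number 28.2 percentage points higher from compound 3 to compound 4 (beyond the scatter) is expected, with wide uncertainty since the core differs. Compound 4 is estimated at 50%, between 5% and 85%.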

Compound 4, a percentage reported as inhibition, in the whole organism at one dose (the size of the read-out at that dose, not a potency): -27.1%
Estimate against measurement, compound 4: 77.1 percentage points above; the measured number lies below the stated range.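

In this assay, methyl in place of isopropyl gave a number 48.9 percentage points lower from compound 3 to compound 4 (beyond the scatter), so the result of this change on one core did not predict its direction on the other: the same change on two cores in this assay, a number 50 percentage points higher (beyond the scatter) from compound 2 to compound 1 and a number 48.9 percentage points lower (beyond the scatter) from compound 3 to compound 4, 98.9 percentage points apart, beyond the scatter of two such steps
Within these two pairs, the outcome therefore depends on the core carrying the change. The pairs do not show which feature of either core is responsible, and two cores cannot give a rule for the wider series.

The compounds shown leave open how an ethyl group, between methyl and isopropyl in chain length, would behave at this place on each core. They also leave open whether a third core would follow either pair.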